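A few compounds are considered here, and "the series" means these few. Any claim that something is new, unique, unknown or untested is made for them only; others in the source may bear on it.

Compound 2, `COc1ccc(F)cc1CNCCCNc1ccnc2cc(-c3ccc(C(C)(C)C)cc3)ccc12`, is the starting point of this step. In a physicochemical assay for acid dissociation, compound 2 gives 9.47. Among the measured compounds shown here, its only measured neighbour is compound 1, `COc1ccc(F)cc1CNCCCNc1ccnc2cc(Cc3ccc(F)cc3Cl)ccc12`, which in this assay gives 9.47; the two values stand level within the scatter. The recorded step between them, no change at the digits printed from compound 1 to compound 2 (within the scatter), swapped one group at the same aromatic carbon that is changed again here, and the read-out did not move.

Compound 3, `COc1ccc(F)cc1CNCCCNc1ccnc2cc(Oc3ccccc3OC)ccc12`, differs from compound 2 by 2-methoxyphenoxy in place of 4-(tert-butyl)phenyl on an aromatic carbon. For the measured compounds named here, the one step that bears on this change is the exchange from compound 1 to compound 2, which was flat, so the expectation is that this further exchange at the same position also leaves this assay unchanged beyond the scatter, that is, a number 0.02 log units lower from compound 2 to compound 3 (within the scatter). Compound 3 is therefore expected to give about 9.45, with a likely range from 9.15 to 9.75.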

Compound 3, acid dissociation constant: 9.28
Compound 3: middle estimate off by 0.17 log units, on the high side; the range from low to high includes it.
By their numbers in this assay, from the lowest: compounds 3, 1 and 2 (each within the scatter of the next).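

In this assay, the exchange to 2-methoxyphenoxy, which brings 2 hydrogen-bond acceptors where 4-(tert-butyl)phenyl has 0, gives a number 0.19 log units lower from compound 2 to compound 3 (within the scatter), and the exchange from the benzyl group gives a number 0.19 log units lower from compound 1 to compound 3 (within the scatter). The three compounds therefore carry quite different groups at this aromatic carbon, 2-chloro-4-fluorobenzyl, 4-(tert-butyl)phenyl and 2-methoxyphenoxy, yet their values all stand within the scatter of one another. No supporting measurement is available to explain this result.

From the compounds shown here alone, whether a group of another kind at this aromatic carbon, such as an amine or a carboxylic acid, would also stay within the scatter remains open. The compounds shown also share everything else in the molecule, so the effect of a change elsewhere, such as a longer chain in place of the shared one, is equally open.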